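A few compounds are considered here, and "the series" means these few. Any claim that something is new, unique, unknown or untested is made for them only; others in the source may bear on it.

In a functional assay on PC-3 cells (Homo sapiens) for inhibition, read by sulforhodamine B assay (a lower number here means a stronger inhibitor of growth, a higher number a weaker inhibitor of growth), compound 1 (`c1ccc(-c2ccc(-c3ccc(-c4nc5ccccc5[nH]4)cc3)cc2)cc1`) gives 41200 nM and compound 2 (`Fc1ccc(-c2ccc(-c3ccc(-c4nc5ccccc5[nH]4)cc3)cc2)cc1`) gives 41200 nM. Compound 3 (`Oc1cccc2[nH]c(-c3ccc(-c4ccc(-c5ccc(F)cc5)cc4)cc3)nc12`) gives 15300 nM, the lowest of the three numbers. Compound 4 (`CN(C)c1ccc(-c2ccc(-c3ccc(-c4nc5c(O)cccc5[nH]4)cc3)cc2)cc1`) has not yet been measured. It differs from compound 3 by dimethylamino in place of fluoro on an aromatic carbon, para to a large group: dimethylamino in place of fluoro on an aromatic carbon.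

Going by the values given here, only one measured step involves a change at that place, fluoro in place of hydrogen, and it gave no change at the digits printed from compound 1 to compound 2 (within the scatter). The other step, hydroxy in place of hydrogen, gave a 2.7-fold lower number from compound 2 to compound 3 (0.43 log units; beyond the scatter), but it concerns a different place and bears on this change only indirectly. Among the compounds with values here, no measured compound carries dimethylamino, so the direction of any change remains open and the range must stay wide. The expected change is small, with no shift beyond the scatter anticipated: a 1.2-fold lower number from compound 3 to compound 4 (0.07 log units; within the scatter). Compound 4 is estimated at 13000 nM, with an expected range from 4500 nM to 38000 nM.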

Compound 4, concentration for 50% growth inhibition: 8420 nM
Compound 4: middle estimate off by 1.5-fold (0.19 log units), on the high side, within the range that was stated.
By their numbers in this assay, from the lowest: compounds 4 and 3 (each within the scatter of the next); then compounds 1 and 2 (each within the scatter of the next).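

In this assay, dimethylamino in place of fluoro on this aromatic carbon gives a 1.8-fold lower number from compound 3 to compound 4 (0.26 log units; within the scatter) and so stays inside the usual scatter. Going by these compounds alone, until now, the only change at this place was the small step to fluoro, no change at the digits printed from compound 1 to compound 2 (within the scatter), whereas this replacement brings in a group of three heavy atoms with a hydrogen-bond acceptor, and the number still moves no further than the scatter allows. Nothing available explains why the change has so little effect here.

On these data alone, it remains open whether a primary amine, a carboxylic acid or a longer alkyl chain at this place would also stay within the scatter. As far as these compounds go, it is equally open whether dimethylamino would behave the same way on the core of compound 1, which lacks the hydroxy group.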